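The source may report more compounds than this note shows. Statements on the series, on what has been measured and on what is new or still open speak of the compounds shown alone.

Measured in an ADME assay for permeability, using PAMPA, with a stated time of 4 h; a lower number here means that the compound crosses the layer more slowly, a higher number that the compound crosses the layer faster:
compound 1 `Cn1c(COc2cccc(C(=O)O)c2)nc2ccc(Oc3ccc(Cl)cn3)cc21`: 16.2 10^-6 cm/s
compound 2 `Cc1cccc(Oc2ccc3nc(COc4cccc(C(=O)O)c4)n(C)c3c2)n1`: 2.7 10^-6 cm/s
compound 3 `Cc1ccnc(Oc2ccc3nc(COc4cccc(C(=O)O)c4)n(C)c3c2)c1`: 3.5 10^-6 cm/s

Compound 3 stands second highest of the three numbers; its nearest neighbour is compound 2, see a 1.3-fold higher number from compound 2 to compound 3 (0.11 log units; within the scatter), within the scatter, while the step that reaches it from the furthest of the three lies beyond the scatter, see a 4.6-fold lower number from compound 1 to compound 3 (0.67 log units; beyond the scatter). Compound 4 `Cn1c(COc2cccc(C(=O)O)c2)nc2ccc(Oc3ccc(F)cn3)cc21` carries 5-fluoropyridin-2-yl in place of 4-methylpyridin-2-yl on an oxygen on an aromatic ring. Going by the values given here, no measured step swaps a methyl-bearing ring for a fluoro-bearing one directly; the steps that bear on it are a 4.6-fold lower number from compound 1 to compound 3 (0.67 log units; beyond the scatter) and a 6.0-fold lower number from compound 1 to compound 2 (0.78 log units; beyond the scatter), both running from the chloro-bearing ring of compound 1 to a methyl-bearing ring. Compound 4 is therefore expected to show a modest upward step in this assay, estimated as a 2.6-fold higher number from compound 3 to compound 4 (0.41 log units; beyond the scatter). Compound 4 is expected to give 9 10^-6 cm/s, between 4 10^-6 cm/s and 18 10^-6 cm/s.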

Compound 4, apparent permeability: 4.7 10^-6 cm/s
Compound 4: middle estimate off by 1.9-fold (0.28 log units), on the high side; low and high end bracket the measured number.
By their numbers in this assay, from the lowest: compounds 2, 3 and 4 (each within the scatter of the next); then compound 1.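

Fluoro in place of chloro on an aromatic carbon is the only step here that changes just the halogen, and in this assay it lies beyond the scatter (a 3.4-fold lower number from compound 1 to compound 4 (0.54 log units; beyond the scatter)). The 5-fluoropyridin-2-yl ring is not separated from either methyl-bearing ring (a 1.3-fold higher number from compound 3 to compound 4 (0.13 log units; within the scatter); a 1.7-fold higher number from compound 2 to compound 4 (0.24 log units; within the scatter)), so on this oxygen only the 5-chloropyridin-2-yl ring of compound 1 stands apart. No measurement on hand accounts for this.

Open: whether a bromo or trifluoromethyl group in place of the chloro would read like compound 1 or like compound 4.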